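Phenyl for hexyl on the sulfonyl oxygen

A few compounds are considered here, and "the series" means these few. Any claim that something is new, unique, unknown or untested is made for them only; others in the source may bear on it.

Three carbamates sharing one core have been measured in an assay on liver for inhibition of sterol O-acyltransferase 1 (Rattus norvegicus), using microsomes; on this read-out higher numbers stand for weaker inhibition and lower numbers for stronger inhibition. Compound 1 `Cc1cc(C(C)(C)C)c(OC(=O)NS(=O)(=O)N(C(C)C)C(C)C)c(C(C)(C)C)c1` gives 3200 nM, compound 2 `CCCCCCCCN(C)S(=O)(=O)NC(=O)Oc1c(C(C)(C)C)cc(C)cc1C(C)(C)C` gives 18000 nM and compound 3 `CCCCCCOS(=O)(=O)NC(=O)Oc1c(C(C)(C)C)cc(C)cc1C(C)(C)C` gives 95000 nM. Compound 3 therefore stands at the highest number of the three, with a 30-fold higher number from compound 1 to compound 3 (1.47 log units; beyond the scatter) and a 5.3-fold higher number from compound 2 to compound 3 (0.72 log units; beyond the scatter), both beyond the scatter, so it is the weakest inhibitor shown. Compound 4 `Cc1cc(C(C)(C)C)c(OC(=O)NS(=O)(=O)Oc2ccccc2)c(C(C)(C)C)c1` differs from compound 3 in one place: phenyl in place of hexyl on an oxygen, the same difference read one bond further out being hexyloxy to phenoxy. Going by the values given here, none of the measured steps touches this spot; each of them, including a 5.6-fold higher number from compound 1 to compound 2 (0.75 log units; beyond the scatter), exchanges the whole group on the sulfonyl sulfur rather than the chain on its oxygen, so they give no direct guide to an aromatic ring in place of a chain. Compound 4 is therefore expected to stay close to compound 3, with a step of a 1.6-fold lower number from compound 3 to compound 4 (0.20 log units; within the scatter) in this assay that need not exceed the scatter. The estimated value of compound 4 is 60000 nM, within a range from 15000 nM to 250000 nM.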

Compound 4, half-maximal inhibitory concentration: 90000 nM
For compound 4 the middle estimate is 1.5-fold (0.18 log units) below the measured one; the measured number falls inside the stated range.
By their numbers in this assay, from the lowest: compound 1; then compound 2; then compounds 4 and 3 (each within the scatter of the next).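

In this assay, putting an aromatic ring in place of a chain on an oxygen whose other neighbour is the sulfonyl sulfur has no readable effect, with a 1.1-fold lower number from compound 3 to compound 4 (0.02 log units; within the scatter) within the scatter, so phenyl and hexyl, each of 6 heavy atoms, cannot be told apart here. Phenoxy stands apart from both amino groups on the sulfonyl sulfur, with a 5.0-fold higher number from compound 2 to compound 4 (0.70 log units; beyond the scatter) and with a 28-fold higher number from compound 1 to compound 4 (1.45 log units; beyond the scatter) as well, which matches the distances already seen for hexyloxy. No measurement is at hand that explains why the ring and the chain read alike.

As far as these compounds go, whether a methyl on that oxygen, or a chlorine or methoxy on the phenyl ring, would depart from these values stays open. So does how a piperidine on the sulfonyl sulfur would compare with the diisopropylamino group of compound 1.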